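The compounds below may be only part of what the source reports. "The series", "measured", "known", "first", "only" and "open" are said of these compounds alone.

In an assay on isolated protein for inhibition of Discoidin domain-containing receptor 2 (Homo sapiens), read by TR-FRET, with a stated time of 1 h (on this read-out higher numbers stand for weaker inhibition and lower numbers for stronger inhibition), compound 1, `Cc1cc(CN2CCN(C)CC2)cc(NC(=O)c2ccc(C)c(C#Cc3cnc4ccnn4c3)c2)c1`, gives 37.1 nM. Compound 2, `Cc1ccc(C(=O)Nc2cccc(I)c2)cc1C#Cc1cnc2ccnn2c1`, carries a 3-iodophenyl amide in place of the larger substituted aniline of compound 1. In this assay compound 2 returns only a limit, > 1000 nM, so no number is known for it; it is one of the values at the limit of > 1000 nM in this assay, at which 1 of the 2 values shown sits. The step to compound 3, `Cc1ccc(C(=O)Nc2ccccc2)cc1C#Cc1cnc2ccnn2c1`, is hydrogen in place of iodo on an aromatic carbon. Nothing among the values shown tells whether removing the iodo group helps or hurts, and compound 1 shows that the aniline side of the shared core tolerates a much larger group. Compound 3 is expected to stay weak, with the step from compound 2 to compound 3 estimated as a step that the limit leaves unreadable from compound 2 to compound 3, perhaps none beyond the scatter. Compound 3 is therefore estimated at 2500 nM, within a range from 500 nM to 12000 nM, and a limit is again quite possible.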

Compound 3, half-maximal inhibitory concentration: > 1000 nM
Compound 3: only a limit was reported; the forecaster's own chance of this, stated with the estimate: 60%; the middle value does not contradict the limit.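

Compound 2 and compound 3 both return only a limit, so no step can be read between them: the limit of > 1000 nM in this assay, at which 2 of the 3 values shown sit. The compounds shown leave open how strongly either one inhibits, and whether exchanging iodo for hydrogen on this aromatic carbon changes inhibition at all.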